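The source may report more compounds than this note shows. Statements on the series, on what has been measured and on what is new or still open speak of the compounds shown alone.

Measured so far in a functional assay on the whole organism (Hindlimb, strain albino) with Mus musculus as the target, in the maximal electroshock model, with a stated time of 0.5 h; a higher number here means that more compound is needed for the effect, a lower number that less compound is needed:
Compound 1 `COc1ccc(/C=C/C(=O)Nc2nc3ccc([N+](=O)[O-])cc3s2)cc1O`: 372 umol/kg
Compound 2 `COc1ccc(/C=C/C(=O)Nc2nc3ccc(C)cc3s2)cc1`: 209 umol/kg

In this assay, compound 2 gives 209 umol/kg and compound 1 gives 372 umol/kg, so these two numbers lie within the usual scatter of each other. Compound 3 `COc1ccc(/C=C/C(=O)Nc2nc3ccc(C)cc3s2)cc1O` keeps everything in compound 2 except for one change: hydroxy in place of hydrogen on an aromatic carbon. This places hydroxy in place of hydrogen on an aromatic carbon, ortho to a methoxy group.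

Among the measured compounds shown here, no pair of measured compounds differs in one place only, so the size of this change has not been measured directly. Compound 1 carries the same hydroxy but also differs elsewhere, and it gives 372 umol/kg. Only a small shift towards a higher number is expected, none beyond the scatter. The estimated step is a 1.2-fold higher number from compound 2 to compound 3 (0.08 log units; within the scatter). For compound 3 the expected value is 250 umol/kg, with an estimated range from 110 umol/kg to 560 umol/kg.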

Compound 3, dose for half-maximal effect: 271 umol/kg
Estimate against measurement, compound 3: 1.1-fold (0.04 log units) below; the range from low to high includes it.
By their numbers in this assay, from the lowest: compounds 2, 3 and 1 (each within the scatter of the next).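

In this assay, among the compounds shown here, this position can now be read directly for the first time: hydroxy in place of hydrogen, ortho to a methoxy group, gives a 1.3-fold higher number from compound 2 to compound 3 (0.11 log units; within the scatter) and so leaves the dose needed indistinguishable from that of the parent compound. With that hydroxy kept, the second site can also be read on its own: methyl in place of nitro on an aromatic carbon gives a 1.4-fold lower number from compound 1 to compound 3 (0.14 log units; within the scatter) and so does not separate the two compounds either. No measurement at hand explains why these two changes leave the numbers so close.

Only hydrogen and hydroxy have been compared at the first site, and only nitro and methyl at the second. As far as these compounds go, whether an amine, a carboxylic acid or a longer chain at either site would move the dose beyond the scatter remains open.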